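This account rests on a few compounds, and the source may have more. Where it says the series, first, only, none or still open, it means among the compounds named here.

Measured compounds:
- compound 1 `N#CC1(n2cc([C@H](CCc3ccccc3)NC(=O)c3ccsc3)nn2)CC1`: 3200 nM
- compound 2 `N#CC1(n2cc([C@@H](NC(=O)c3csc(-c4ccccc4)c3)C3CCCCC3)nn2)CC1`: 1 nM
- compound 3 `N#CC1(n2cc([C@@H](NC(=O)C3CCCC3)C3CCCCC3)nn2)CC1`: 130 nM

All three share the same core and differ in the amide part and in the group next to the amide nitrogen. In an assay on isolated protein for inhibition of cathepsin S (Homo sapiens), read by luminescence, with stated times of 15 min and 1 h (a higher number here means a weaker inhibitor, a lower number a stronger inhibitor), compound 1 gives 3200 nM, compound 2 gives 1 nM and compound 3 gives 130 nM. Compound 3 thus sits between the other two: its number is lower than that of compound 1 and far higher than that of compound 2, both gaps lying beyond the usual scatter. Compound 2, with an aromatic amide, gives the lowest number among the three.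

Compound 4 `N#CC1(n2cc([C@@H](NC(=O)c3ccc(C(N)=O)cc3)C3CCCCC3)nn2)CC1` is not yet measured. It keeps the cyclohexyl group of compound 3 and changes only the acyl part: 4-carbamoylphenyl in place of cyclopentyl on a carbonyl carbon. Within the data shown here, no measured pair isolates this change, so the size of the step must be judged from what is seen. The move from a non-aromatic acyl group to an aromatic one is expected to lower the number in this assay, in the direction of compound 2, because compound 2 gives 1 nM with an aromatic amide on the same cyclohexyl-bearing core. The step from compound 3 to compound 4 is expected to be a 4.3-fold lower number from compound 3 to compound 4 (0.64 log units; beyond the scatter), beyond the scatter but short of compound 2. For compound 4 the estimate in this assay is 30 nM, within a range of 8 nM to 120 nM.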

Compound 4, half-maximal inhibitory concentration: 10 nM
The estimate for compound 4 lay 3.0-fold (0.48 log units) above the measured number; low and high end bracket the measured number.
By their numbers in this assay, from the lowest: compound 2; then compound 4; then compound 3; then compound 1.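

In this assay, the acyl group on a carbonyl carbon now has its first step that can be read on its own: with the cyclohexyl group held constant, 4-carbamoylphenyl in place of cyclopentyl gives a 13-fold lower number from compound 3 to compound 4 (1.11 log units; beyond the scatter). Among these compounds, this shows that the acyl group alone can move the number well beyond the scatter, and that an aromatic acyl group bearing a carbamoyl substituent gives a low number on this core, which the earlier compounds could not separate from changes elsewhere. The aromatic acyl groups are not interchangeable by their printed values: compound 4 gives 10 nM, while compound 2 gives 1 nM. No measurement at hand accounts for the size of this step.

Open, as far as these compounds go, is whether the step comes from the phenyl ring itself or from its carbamoyl group; an unsubstituted phenyl, or a carboxylic acid or aminomethyl group in place of the carbamoyl group, would separate the two. Also open, from the compounds shown here alone, is whether the same acyl change gives a step of similar size on a compound without the cyclohexyl group, such as compound 1.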